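A few compounds are considered here, and "the series" means these few. Any claim that something is new, unique, unknown or untested is made for them only; others in the source may bear on it.

In an assay on cells for agonist activity at ecdysone receptor (Bombyx mori), read by a luciferase reporter, with a stated time of 24 h (a lower number here means that less compound is needed, a higher number that more compound is needed for the effect), three compounds have been measured so far:

compound 1, `CC(C)(C)N(NC(=O)c1ccccc1)C(=O)c1ccccc1I`, giving 105 nM;
compound 2, `Cc1ccccc1C(=O)N(NC(=O)c1ccccc1)C(C)(C)C`, giving 224 nM;
compound 3, `CC(C)(C)N(NC(=O)c1ccccc1I)C(=O)c1ccccc1Cl`, giving 1290 nM.

Compound 1 and compound 2 differ in one place, (methyl in place of iodo on an aromatic carbon), and this change produced a 2.1-fold higher number from compound 1 to compound 2 (0.33 log units; beyond the scatter). Compound 3 stands highest of the three values measured. How the core of compound 3 differs from the core of compound 1 is not broken down here.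

Compound 4, `Cc1ccccc1C(=O)NN(C(=O)c1ccccc1Cl)C(C)(C)C`, has not yet been measured. It differs from compound 3 by methyl in place of iodo on an aromatic carbon, the same change at a place described in the same words. Because the earlier change gave a 2.1-fold higher number from compound 1 to compound 2 (0.33 log units; beyond the scatter), a step of similar size is expected here, namely a 2.1-fold higher number from compound 3 to compound 4 (0.32 log units; beyond the scatter). Compound 4 is therefore expected to give about 2700 nM, estimated to lie between 1000 nM and 7000 nM.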

Compound 4, half-maximal effective concentration: 72.4 nM
Beside the measured number, compound 4's estimate is 37-fold (1.57 log units) above it, and the stated range ends above it.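

In this assay, putting methyl in place of iodo on an aromatic carbon gave an 18-fold lower number from compound 3 to compound 4 (1.25 log units; beyond the scatter), so the step seen on the first core did not carry over to the second in either size or direction: the same change on two cores in this assay, a 2.1-fold higher number (0.33 log units; beyond the scatter) from compound 1 to compound 2 and an 18-fold lower number (1.25 log units; beyond the scatter) from compound 3 to compound 4, 38-fold (1.58 log units) apart, beyond the scatter of two such steps

In this series, then, the result of this change depends on the core that carries it, and a step read on one core is no safe guide to the same step on another. Among the compounds shown here, with only two pairs, this does not show why the cores differ or how a further core would respond.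

From the compounds shown here alone, it remains open how other groups on the same aromatic carbon, such as an amine, a carboxylic acid or a longer chain, would behave on these two cores.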